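Methyl for Hydrogen on a Ring Nitrogen: Expecting Compound 4

The source may report more compounds than this note shows. Statements on the series, on what has been measured and on what is new or still open speak of the compounds shown alone.

Three compounds have been measured in a functional assay on HeLa cells (Homo sapiens) for inhibition, read by MTT assay, with a stated time of 24 h; a higher number here means a weaker inhibitor, a lower number a stronger inhibitor:
compound 1, `CO/N=C1\C[C@@H](c2ccc(C)cc2)N[C@@H](c2ccc(C)cc2)[C@@H]1C`, gives 81600 nM;
compound 2, `CC[C@@H]1/C(=N/OC)C[C@@H](c2ccccc2)N[C@H]1c1ccccc1`, gives 57300 nM;
compound 3, `CO/N=C1\C[C@@H](c2ccc(C)cc2)N(C)[C@@H](c2ccc(C)cc2)[C@@H]1C`, gives 47700 nM.

Compound 1 and compound 3 differ by a single change, (methyl in place of hydrogen on an amine nitrogen in a ring), and this change made a step of a 1.7-fold lower number from compound 1 to compound 3 (0.23 log units; within the scatter). Compound 2 and compound 3 show numbers that lie within the scatter of each other, as do compound 2 and compound 1. How the core of compound 2 differs from the core of compound 1 is not broken down here.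

Compound 4, `CC[C@@H]1/C(=N/OC)C[C@@H](c2ccccc2)N(C)[C@H]1c1ccccc1`, has not yet been measured. It is made from compound 2 by methyl in place of hydrogen on an amine nitrogen in a ring. Among the measured compounds shown here, this is the same kind of change as the one from compound 1 to compound 3, but the surroundings differ: in compound 2 the ring atoms on either side bear a phenyl group rather than a 4-methylphenyl group, and the ring atom two bonds away bears an ethyl group rather than a methyl group. The step from compound 2 to compound 4 is expected to be a 1.5-fold lower number from compound 2 to compound 4 (0.18 log units; within the scatter), resting on compound 1 and compound 3, whose step a 1.7-fold lower number from compound 1 to compound 3 (0.23 log units; within the scatter) stayed within the scatter. Compound 4 is therefore estimated to give 38000 nM in this assay, with a range of 15000 nM to 90000 nM.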

Compound 4, half-maximal inhibitory concentration: 41700 nM
For compound 4 the middle estimate is 1.1-fold (0.04 log units) below the measured one, within the range that was stated.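

In this assay, methyl in place of hydrogen on the amine nitrogen in the ring gives a 1.4-fold lower number from compound 2 to compound 4 (0.14 log units; within the scatter), so on this second core the change again leaves the number within the usual scatter of repeated measurements. Set side by side, the two steps agree: the same change on two cores in this assay, a 1.7-fold lower number (0.23 log units; within the scatter) from compound 1 to compound 3 and a 1.4-fold lower number (0.14 log units; within the scatter) from compound 2 to compound 4, 1.2-fold (0.10 log units) apart, within the scatter of two such steps This shows that, across these two cores, the change carried over without any step that stands out from the scatter, but it does not show that the methyl has a real effect on the number in either core, since a step this small cannot be told apart from repeat-to-repeat variation, and two cores say nothing certain about a third.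

The compounds shown leave open whether a larger group on that nitrogen, such as a propyl chain or a benzyl group, would give a step beyond the scatter. They also leave open whether the same change behaves alike when the phenyl groups carry something other than methyl, such as a chlorine atom or a methoxy group.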